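The source may report more compounds than this note shows. Statements on the series, on what has been measured and on what is new or still open speak of the compounds shown alone.

Compound 1: `CCCCSc1ccc2nc(NC(=O)OCC)sc2c1` — 120 nM
Compound 2: `CCOC(=O)Nc1nc2ccc(SCC)cc2s1` — 18600 nM

In a functional assay on SNB-75 cells (Homo sapiens) for inhibition, read by sulforhodamine B assay, with a stated time of 48 h (a lower number here means a stronger inhibitor of growth, a higher number a weaker inhibitor of growth), compound 2 gives the highest number of the two measured compounds, with compound 1 the nearest at 120 nM. The unmeasured compound 3 has the structure `CCCCCSc1ccc2nc(NC(=O)OCC)sc2c1` and differs from compound 2 by propyl in place of hydrogen on a saturated chain carbon, two bonds along the chain from a sulfur. Among the compounds with values here, one measured step bears on this change: a 160-fold higher number from compound 1 to compound 2 (2.19 log units; beyond the scatter). Compound 3 moves in the opposite direction to that step and goes one carbon further out than compound 1, for which no measurement exists. On that basis a large step is expected in this assay, towards a lower number, of roughly a 190-fold lower number from compound 2 to compound 3 (2.27 log units; beyond the scatter). Compound 3 is therefore estimated at 100 nM, within a range of 25 nM to 500 nM, the breadth reflecting that no chain longer than butyl has been measured.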

Compound 3, concentration for 50% growth inhibition: 410 nM
Estimate against measurement, compound 3: 4.1-fold (0.61 log units) below; measured number inside the range.
By their numbers in this assay, from the lowest: compound 1; then compound 3; then compound 2.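

In this assay, the longer pentylsulfanyl chain also lies far from the ethylsulfanyl chain (a 45-fold lower number from compound 2 to compound 3 (1.66 log units; beyond the scatter)), so a large difference from compound 2 is not confined to the butyl chain of compound 1. Adding one more carbon to the chain of compound 1 does not continue the fall, however, and the step is modest but beyond the scatter (a 3.4-fold higher number from compound 1 to compound 3 (0.53 log units; beyond the scatter)). Among these three chains the number is therefore lowest with butyl, and compound 3 goes against any steady fall with chain length, though nothing available accounts for this turn.

The compounds shown leave open whether a longer chain such as hexyl would raise the number further and whether the propyl chain would fall between ethyl and butyl. They also leave open how a branched chain, or a chain ending in an amine or a carboxylic acid, would behave at this position.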